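Working notes: from compound 2 to compound 4

The source may hold more compounds than are shown below. What is called first, only, known or untested is meant among the compounds shown, and "the series" means these compounds.

- compound 1 `COc1ccc(OC)c(NC(=O)CCCCCCNC(=O)C(O)(O)C(F)(F)F)c1`: 3870 nM
- compound 2 `O=C(CCCCCCNC(=O)C(O)(O)C(F)(F)F)Nc1ccccc1Br`: 14500 nM
- compound 3 `O=C(CCCCCCNC(=O)C(O)(O)C(F)(F)F)Nc1nc(-c2ccccc2)c(-c2ccccc2)s1`: 29900 nM

All three values come from a functional assay on HCT-116 cells (Homo sapiens) for inhibition, read by colorimetric assay, with a stated time of 3 days; a lower number here means a stronger inhibitor, a higher number a weaker inhibitor. Compound 2, at 14500 nM, stands in the middle of the three numbers. Compound 1 gives the lowest number and compound 3 the highest, and the gap from compound 2 to each of them lies beyond the usual scatter.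

The next compound to be read is compound 4 `O=C(CCCCCCNC(=O)C(O)(O)C(F)(F)F)Nc1c(F)cc(F)cc1F`. The change is 2,4,6-trifluorophenyl in place of 2-bromophenyl on an amide-type nitrogen.

Going by the values given here, the series offers no measured step between two compounds to serve as a guide, so the expectation rests on the overall spread alone. That spread runs from compound 1 at 3870 nM to compound 3 at 29900 nM, and compound 2 lies inside it. With nothing to set a direction firmly, a step beyond the scatter is not expected in this assay. The expected change is a 1.2-fold lower number from compound 2 to compound 4 (0.08 log units; within the scatter), a small shift towards a lower number at most. For compound 4 the estimated value is 12000 nM, with an expected range of 4000 nM to 30000 nM.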

Compound 4, half-maximal inhibitory concentration: 22200 nM
Compound 4: the middle estimate sits 1.9-fold (0.27 log units) below what was measured; low and high end bracket the measured number.
By their numbers in this assay, from the lowest: compound 1; then compounds 2, 4 and 3 (each within the scatter of the next, the first and the last beyond it).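

In this assay, going by these compounds alone, the exchange of 2-bromophenyl for 2,4,6-trifluorophenyl on an amide-type nitrogen gives a 1.5-fold higher number from compound 2 to compound 4 (0.18 log units; within the scatter), the only step that can be read directly. At this place, then, a single bromine can give way to three fluorines without a change beyond the scatter, while the six-membered aromatic ring of carbon only stays and neither group brings hydrogen-bond donors or acceptors or a net charge. No measurement on either compound bears on why the two read alike, so the step stands as an observation only.

On these data alone, the step covers only these two halogen-bearing phenyl groups, so it remains open how the number responds to a plain phenyl, or to a phenyl carrying an amine or a carboxylic acid, at the same place. Also open is whether a longer chain on the shared core would move the number, since all the compounds shown keep the same chain and only the group on the amide-type nitrogen varies.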